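The source may report more compounds than this note shows. Statements on the series, on what has been measured and on what is new or still open speak of the compounds shown alone.

Measured so far in a functional assay on SW-620 cells (Homo sapiens) for inhibition, read by sulforhodamine B assay, with a stated time of 48 h; on this read-out lower numbers stand for stronger inhibition of growth and higher numbers for weaker inhibition of growth:
compound 1, `CCOC(=O)[C@H](CCC(=O)O)NC(=O)c1ccc(Sc2nc3cc(N)cc(N)c3nc2-c2ccccc2)cc1`, gives 11700 nM;
compound 2, `Nc1cc(N)c2nc(-c3ccccc3)c(Sc3ccc(F)cc3)nc2c1`, gives 22900 nM.
For compound 3, `CCOC(=O)[C@H](CCC(=O)O)NC(=O)c1ccc(CNc2nc3cc(N)cc(N)c3nc2-c2ccccc2)cc1`, only a limit of the assay is recorded, < 100000 nM; its value is the limit of < 100000 nM in this assay, at which 1 of the 3 values shown sits.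

Among the two numbers compound 2 stands highest, but its gap to compound 1 lies within the usual scatter, so the two read as equivalent in this assay. For the measured compounds named here, no pair of measured compounds differs in a single place, so no step size is known from measurement.

Compound 4, `Nc1cc(N)c2nc(-c3ccccc3)c(NCc3ccc(F)cc3)nc2c1`, is the unmeasured partner of compound 2. The change is (4-fluorobenzyl)amino in place of (4-fluorophenyl)sulfanyl on an aromatic carbon. In this assay, going by the values given here, no comparable step has been measured, and the only related pair, compound 1 against compound 3, yields a number against a limit and so shows no size of effect. The step from compound 2 to compound 4 is therefore expected to be modest, in the direction of weaker growth inhibition, estimated as a 1.5-fold higher number from compound 2 to compound 4 (0.18 log units; within the scatter). Compound 4 is estimated at 35000 nM, with a range from 10000 nM to 100000 nM.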

Compound 4, concentration for 50% growth inhibition: 2190 nM
Beside the measured number, compound 4's estimate is 16-fold (1.20 log units) above it, outside the stated range (below it).
By their numbers in this assay, from the lowest: compound 4; then compounds 1 and 2 (each within the scatter of the next).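

In this assay, the position on the aromatic carbon next to the ring nitrogen and ortho to a phenyl group proves sensitive to this change: (4-fluorobenzyl)amino in place of (4-fluorophenyl)sulfanyl gives a 10-fold lower number from compound 2 to compound 4 (1.02 log units; beyond the scatter). For the compounds shown here, this is the first step measured at this position, and it is a large one. Both groups carry a six-membered aromatic ring of carbon only and a fluorine, so the step goes with the link to the core and not with a change of ring type.

A (4-fluorophenyl)amino or a (4-fluorobenzyl)sulfanyl group would be needed to separate the nitrogen of the link from its extra carbon. Compound 3 is recorded only at a limit of the assay, so whether the step carries over from compound 1 to compound 3 cannot be read: the limit of < 100000 nM in this assay, at which 1 of the 4 values shown sits.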